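From Fluoro to Methoxy: an Expectation for Compound 4

This account rests on a few compounds, and the source may have more. Where it says the series, first, only, none or still open, it means among the compounds named here.

Measured so far: compound 1 `CC1(C)CC(=O)C2=C(C1)N(c1ccccc1)C(c1cccc(C(F)(F)F)c1)N(c1ccccc1)C2` with 17900 nM; compound 2 `CC1(C)CC(=O)C2=C(C1)N(c1ccccc1)C(c1ccc(Br)cc1)N(c1ccc(Cl)cc1)C2` with 12700 nM; compound 3 `CC1(C)CC(=O)C2=C(C1)N(c1ccc(F)cc1)C(c1ccc(Br)cc1)N(c1ccc(Cl)cc1)C2` with a limit of > 20000 nM.

In an ADME assay on BHK-21 cells (Mesocricetus auratus) for cytotoxicity, read by MTT assay, with a stated time of 48 h (a higher number here means that more compound is tolerated, a lower number that less compound is tolerated), compound 1 gives 17900 nM and compound 2 gives 12700 nM. For compound 3 the read-out is a limit, > 20000 nM, not a number, and the step of an at least 1.5-fold higher number from compound 2 to compound 3 (0.19 log units; that floor lies within the scatter) therefore has only a floor. Compound 3 thus stands at the edge of what this assay reports, as recorded in the limit of > 20000 nM in this assay, at which 1 of the 3 values shown sits.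

Compound 4 `COc1ccc(N2C3=C(CN(c4ccc(Cl)cc4)C2c2ccc(Br)cc2)C(=O)CC(C)(C)C3)cc1` differs from compound 3 by methoxy in place of fluoro on an aromatic carbon. Going by the values given here, the one measured step that touches the same place, an at least 1.5-fold higher number from compound 2 to compound 3 (0.19 log units; that floor lies within the scatter), exchanged hydrogen for fluoro and produced at best a small rise whose floor sits within the scatter; no measured step exchanges fluoro for methoxy, so nothing here points to a change beyond the scatter in either direction.

Compound 4 is therefore expected to remain at or near the limit, with an expected step of a number no higher from compound 3 to compound 4 (the limit leaves the size open). The estimate for compound 4 in this assay is 20000 nM, ranging from 10000 nM to 40000 nM, with a fair chance that only a limit is reported again.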

Compound 4, half-maximal cytotoxic concentration: > 20000 nM
Compound 4 was reported as a limit; the forecaster's own chance of this, stated with the estimate: 50%; the middle value sits exactly at the limit.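

Methoxy on an aromatic carbon para to a large group behaves as fluoro did in this assay, so a second, larger replacement of hydrogen at this place also leaves the read-out at the edge of what is reported: the limit of > 20000 nM in this assay, at which 2 of the 4 values shown sit. With hydrogen as the starting point, the new group gives an at least 1.5-fold higher number from compound 2 to compound 4 (0.19 log units; that floor lies within the scatter), which matches the floor of an at least 1.5-fold higher number from compound 2 to compound 3 (0.19 log units; that floor lies within the scatter), so neither replacement has yet been shown to move the number beyond the scatter, and neither has been seen to lower it. The exchange of 4-fluorophenyl for 4-methoxyphenyl itself cannot be read, as both ends are limits, so fluoro and methoxy cannot be ordered against each other.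

The compounds shown leave open how far past the limit compound 3 and compound 4 lie, and whether an amine, a carboxylic acid or a longer chain at this same place would bring the read-out back to a number. Also open, as far as these compounds go, is whether methoxy would read the same way on the core of compound 1, which carries different groups elsewhere.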